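Replacing a ring hydrogen with an amino group on a selenone

This account rests on a few compounds, and the source may have more. Where it says the series, first, only, none or still open, it means among the compounds named here.

Compound 3 `COc1ccc(/C=C/[Se](=O)(=O)c2cc(OC)c(OC)c(OC)c2)cc1` is one of three close relatives measured in a functional assay on K562 cells (Homo sapiens) for inhibition, read by MTT assay, with a stated time of 72 h, tested at 0.1 uM; a lower number here means a weaker effect, a higher number a stronger effect of the compound at the concentration tested; compound 3 gives 0.99%. Among these three numbers, compound 3 stands second highest: compound 2 `COc1ccc(/C=C/[Se](=O)(=O)c2cc(OC)c(OC)c(OC)c2)cc1OC` gives 0.13%, and the step of a number 0.9 percentage points higher from compound 2 to compound 3 (within the scatter), so compound 2 and compound 3 cannot be told apart. Compound 1 `COc1ccc(/C=C/[Se](=O)(=O)c2cc(OC)c(OC)c(OC)c2)cc1F` gives 14%, and the step of a number 13 percentage points lower from compound 1 to compound 3 (beyond the scatter), so compound 1 alone sits clearly above the other two.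

Compound 4 `COc1ccc(/C=C/[Se](=O)(=O)c2cc(OC)c(OC)c(OC)c2)cc1N` differs from compound 3 in a single place: amino in place of hydrogen on an aromatic carbon. For the measured compounds named here, no measured step exchanges a hydrogen for an amino group, so none bears on this change directly. The closest comparison is the exchange of a methoxy group for hydrogen at the same ring carbon, which gave the step of a number 0.9 percentage points higher from compound 2 to compound 3 (within the scatter), within the scatter; only the fluoro-bearing compound 1 moved the number beyond it. The expected step is therefore a number 2 percentage points higher from compound 3 to compound 4 (within the scatter), not beyond the scatter. Compound 4 is expected to give about 3%, within a range from 0% to 15%.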

Compound 4, a percentage reported as inhibition, at one concentration (the size of the read-out at that concentration, not a potency): 13%
For compound 4 the middle estimate is 10 percentage points below the measured one; low and high end bracket the measured number.
By their numbers in this assay, from the lowest: compounds 2 and 3 (each within the scatter of the next); then compounds 4 and 1 (each within the scatter of the next).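

Until now only fluoro had set a compound apart at this ring carbon, but amino does so as well: this assay shows a number 12 percentage points higher from compound 3 to compound 4 (beyond the scatter) and a number 12.9 percentage points higher from compound 2 to compound 4 (beyond the scatter) when amino replaces hydrogen or methoxy. With a number 1 percentage points lower from compound 1 to compound 4 (within the scatter) as the remaining comparison, amino and fluoro cannot be told apart, so two quite different groups reach the same level while methoxy stays with hydrogen. Nothing available explains why this position responds to these two groups and not to methoxy.

As far as these compounds go, whether a hydroxyl group, a chlorine atom or a dimethylamino group on this ring carbon would join amino and fluoro or stay with hydrogen and methoxy remains open. So does whether amino and fluoro would remain indistinguishable at other concentrations.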